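A few compounds are considered here, and "the series" means these few. Any claim that something is new, unique, unknown or untested is made for them only; others in the source may bear on it.

Three compounds share a common core joined through a sulfonyl group to an aromatic ring and to a saturated nitrogen-containing ring. Compound 1 `CC1CCN(c2c(S(=O)(=O)c3cc(F)cc(F)c3)cnc3cc(Cl)ccc23)CC1` carries a fluorine-bearing phenyl ring; in an assay on isolated protein for displacement of a labelled ligand from metabotropic glutamate receptor 5 (Homo sapiens), with a stated time of 60 min (on this read-out lower numbers stand for stronger inhibition and higher numbers for weaker inhibition), compound 1 gives 195 nM. Compound 2 `CC1CCN(c2c(S(=O)(=O)c3ccc(Cl)c(Cl)c3)cnc3ccc(Cl)cc23)CC1` carries a 3,4-dichlorophenyl ring instead; in this assay compound 2 gives 55.6 nM. Compound 3 `CCN1CCN(c2c(S(=O)(=O)c3ccccc3)cnc3ccccc23)CC1` has an unsubstituted phenyl ring and a different saturated ring; in this assay compound 3 gives "not determined" (no result reported), so no number is available for it. Of the two numbers available, compound 2 stands lowest, and its gap to compound 1 lies beyond the usual scatter of repeated measurements.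

Compound 4 `CC1CCN(c2c(S(=O)(=O)c3ccc(Cl)cc3)cnc3ccc(Cl)cc23)CC1` differs from compound 2 by hydrogen in place of chloro on an aromatic carbon, so the 3,4-dichlorophenyl ring becomes a 4-chlorophenyl ring. Among the measured compounds shown here, no measured pair shows this change directly, so the expectation rests on compound 2 alone. Removing one chloro is expected to cost a little potency, giving a somewhat higher number, likely close to the edge of the scatter, an expected step of a 2.3-fold higher number from compound 2 to compound 4 (0.37 log units; beyond the scatter). Compound 4 is therefore estimated at 130 nM, with a plausible range from 55 nM to 320 nM.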

Compound 4, inhibition constant: 435 nM
For compound 4 the middle estimate is 3.3-fold (0.52 log units) below the measured one; measured number above the stated range.
By their numbers in this assay, from the lowest: compound 2; then compound 1; then compound 4.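

In this assay replacing the chloro group that is ortho to a chloro group and meta to a large group with hydrogen gives a 7.8-fold higher number from compound 2 to compound 4 (0.89 log units; beyond the scatter) and so weakens inhibition by a margin beyond the usual scatter. This is the first direct pair among these compounds, and it shows that this single chlorine contributes measurably to the inhibition seen with compound 2, while the chloro left on the 4-chlorophenyl ring does not make up for its loss. No independent evidence bears on why the step has this size.

From the compounds shown here alone, whether a methyl, a methoxy or an amine in this place would restore inhibition remains open. Also open, going by these compounds, is whether the step would keep its size with the chloro on the shared core placed as in compound 1.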